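The source may hold more compounds than are shown below. What is called first, only, known or untested is meant among the compounds shown, and "the series" means these compounds.

In an ADME assay on Vero cells (Chlorocebus sabaeus) for cytotoxicity, read by CellTiter-Glo, with a stated time of 72 h (on this read-out lower numbers stand for higher toxicity in this test and higher numbers for lower toxicity in this test), three compounds built on one shared core lie close together. Compound 1 `CC(C)(C)Nc1n[n+]([O-])c2ccccc2[n+]1[O-]` gives 8 ug/mL, compound 2 `[O-][n+]1nc(NC2CCC2)[n+]([O-])c2ccccc21` gives 8.9 ug/mL, and compound 3 `[O-][n+]1nc(NC2CCCCC2)[n+]([O-])c2ccccc21` gives 8.9 ug/mL. Compound 3 thus stands level with compound 2 and within the scatter of compound 1. Compound 4 `[O-][n+]1nc(NC2CCCCC2)[n+]([O-])c2ccc(F)cc21` keeps the cyclohexyl group of compound 3 and differs on the core: fluoro in place of hydrogen on an aromatic carbon.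

The measured steps all concern the group on the nitrogen: a 1.1-fold higher number from compound 1 to compound 2 (0.05 log units; within the scatter), a 1.1-fold higher number from compound 1 to compound 3 (0.05 log units; within the scatter) and no change at the digits printed from compound 2 to compound 3 (within the scatter). Each lies within the scatter, but none involves an aromatic carbon of the core, so they bear on this change only indirectly. Going by the values given here, the data contain no measured fluoro compound. With so little to go on, no step beyond the scatter is expected, and no firm direction can be given. The estimated change is a 1.1-fold lower number from compound 3 to compound 4 (0.05 log units; within the scatter). For compound 4 the expected value is 8 ug/mL, with an estimated range from 3.5 ug/mL to 16 ug/mL.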

Compound 4, half-maximal cytotoxic concentration: < 2.5 ug/mL
Compound 4: no number, only a limit (the forecaster's own chance of this, stated with the estimate: 3%); at least 3.2-fold (0.50 log units) between middle value and limit.
By their numbers in this assay, from the lowest: compounds 1, 2 and 3 (each within the scatter of the next). At a limit, below all of these: compound 4.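

The earlier steps shown here all changed the group on the nitrogen, and all stayed within the scatter. The first change on the core, fluoro in place of hydrogen on an aromatic carbon, meta to a fused ring and para to a fused ring, gives an at least 3.5-fold lower number from compound 3 to compound 4 (0.55 log units; beyond the scatter), so in this assay, where a lower number stands for higher toxicity, this position responds to a single fluoro as none of the nitrogen groups shown did. Compound 4 has no number, only a limit, and the full size of the step stays unknown: the limit of < 2.5 ug/mL in this assay, at which 1 of the 4 values shown sits.

From the compounds shown here alone, whether chloro, methoxy or an amine on this same aromatic carbon would lower the number too stays open, as does the effect of fluoro on another aromatic carbon of the core. Equally open, going by these compounds, is whether the step would appear with tert-butyl or cyclobutyl on the nitrogen in place of cyclohexyl.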